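The source may hold more compounds than are shown below. What is called first, only, known or untested is meant among the compounds shown, and "the series" means these compounds.

Two sulfonate esters share a core in which an isopropyl-substituted phenol is linked through a sulfonyl group to an aniline that carries an amide. Compound 1 `CCCC(=O)Nc1cccc(S(=O)(=O)Oc2ccccc2C(C)C)c1` bears a butanamide; in a functional assay on HT-1080 cells (Homo sapiens) for antiproliferative activity, read by sulforhodamine B assay, with a stated time of 48 h (a lower number here means a stronger inhibitor, a higher number a weaker inhibitor), compound 1 gives 15000 nM. Going by the values given here, compound 2 `CC(C)c1ccccc1OS(=O)(=O)c1cccc(NC(=O)CCl)c1` carries a chloroacetamide instead, and in this assay compound 2 gives 780 nM, the lowest of the two numbers so far; the only step measured, a 19-fold lower number from compound 1 to compound 2 (1.28 log units; beyond the scatter), is large. Compound 3 `CC(C)c1ccccc1OS(=O)(=O)c1cccc(NC(=O)CCCl)c1` is the next member: the change is chloromethyl in place of chloro on a saturated chain carbon bound to a carbonyl carbon. Among the compounds with values here, that step moves the chlorine one carbon further from the carbonyl, so compound 3 sits between the two measured structures rather than extending a measured trend, and the one measured step gives only a loose guide. Compound 3 is estimated at about 8000 nM. Its expected range runs from 2000 nM to 30000 nM. The expected step is a 10-fold higher number from compound 2 to compound 3 (1.01 log units; beyond the scatter).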

Compound 3, half-maximal inhibitory concentration: 8200 nM
Estimate against measurement, compound 3: 1.0-fold (0.01 log units) below; measured number inside the range.
By their numbers in this assay, from the lowest: compound 2; then compounds 3 and 1 (each within the scatter of the next).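

In this assay, the place of the chlorine matters: with chloromethyl replaced by 2-chloroethyl on the amide chain, the result is an 11-fold higher number from compound 2 to compound 3 (1.02 log units; beyond the scatter). Having a chlorine somewhere on this chain is therefore not enough to give the low number, since the comparison with the chlorine-free butanamide gives a 1.8-fold lower number from compound 1 to compound 3 (0.26 log units; within the scatter), and among these three compounds only the chloroacetamide stands apart. Nothing available here explains why moving the chlorine by one carbon has this effect.

The compounds shown leave open whether chlorine itself is needed on the saturated chain carbon bound to the carbonyl carbon, which a bromo or an amine at that place would test. A longer chain ending in chlorine would show whether the number changes further as the chlorine moves outward.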